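Nitro to hydroxy in the series

A few compounds are considered here, and "the series" means these few. Any claim that something is new, unique, unknown or untested is made for them only; others in the source may bear on it.

Two members of the series have been read so far in a functional assay on SK-MEL cells (Homo sapiens) for cytotoxicity, read by MTT assay, with a stated time of 6 days; on this read-out lower numbers stand for an effect already at smaller amounts and higher numbers for an effect only at larger amounts of compound. Among the compounds with values here, compound 1 (`COC(=O)c1c(-c2ccc(O)cc2)oc2ccc(OC)cc2c1=O`) gives 18.7 ug/mL, the only true number available. Compound 2 (`COc1ccc2oc(-c3ccc([N+](=O)[O-])cc3)c(C(=O)O)c(=O)c2c1`) gives > 25 ug/mL, which is a limit of the assay and not a number. As far as these compounds go, its standing is therefore open on one side, and its true value remains unknown.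

Compound 3 (`COc1ccc2oc(-c3ccc(O)cc3)c(C(=O)O)c(=O)c2c1`) is the next to be read. It follows from compound 2 by a single exchange, hydroxy in place of nitro on an aromatic carbon, para to a large group: hydroxy in place of nitro on an aromatic carbon. Within the data shown here, no measured pair sizes this exchange, so the expectation is a cautious one. No step beyond the usual scatter is expected in this assay, and any movement would more likely be towards smaller amounts. The expected change is an at least 1.0-fold lower number from compound 2 to compound 3 (0.01 log units; that floor lies within the scatter). The scale of this expectation is set by compound 1 at 18.7 ug/mL. A further reading that returns only a limit remains quite possible. For compound 3 the estimate is 24 ug/mL, with an expected range of 12 ug/mL to 50 ug/mL.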

Compound 3, concentration for half-maximal effect: > 25 ug/mL
Compound 3: a limit, no number; the forecaster's own chance of this, stated with the estimate: 50%; at least 1.0-fold (0.01 log units) between middle value and limit.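

In this assay compound 3 gives > 25 ug/mL, a limit of the assay and not a number, and the step for hydroxy in place of nitro from compound 2 cannot be read, because both compounds sit at the same limit: the limit of > 25 ug/mL in this assay, at which 2 of the 3 values shown sit.

Within the data shown here, the one readable comparison is hydrogen in place of methyl on an oxygen next to a carbonyl group, which gives an at least 1.3-fold higher number from compound 1 to compound 3 (0.12 log units; that floor lies within the scatter). This is a floor and not a size, so the pair does not establish a step beyond the scatter, though the true step could be larger. Among these compounds, with the hydroxy on the aromatic ring held constant, the only true number so far belongs to compound 1, which carries the methyl on that oxygen, while the free carboxylic acid of compound 3 returns only a limit.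

As far as these compounds go, how far compound 2 and compound 3 lie beyond the limit stays open, and so does whether the exchange of nitro for hydroxy has any real size. Also open, from the compounds shown here alone, is what the methyl on that oxygen would give with nitro on the ring, and what an amine on the same aromatic carbon or a longer chain in place of the methyl would give.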